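Cytotoxicity notes on a benzoxazole acid amide series

The source may hold more compounds than are shown below. What is called first, only, known or untested is meant among the compounds shown, and "the series" means these compounds.

Measured so far:
Compound 1, `O=C(Nc1c(O)cccc1-c1nc2c(C(=O)O)cccc2o1)c1ncccc1F`: 204000 nM
Compound 2, `O=C(Nc1c(O)cccc1-c1nc2c(C(=O)O)cccc2o1)c1ccc(F)c(F)c1F`: 210000 nM

Two amides on a shared core have been read in an ADME assay on L6 cells (Rattus norvegicus) for cytotoxicity; a higher number here means a weaker inhibitor, a lower number a stronger inhibitor. Compound 1 gives 204000 nM, and compound 2 gives 210000 nM. The one step between them, a 1.0-fold higher number from compound 1 to compound 2 (0.01 log units; within the scatter), is within the scatter, so on the two numbers shown compound 1 and compound 2 are indistinguishable, and neither can be called the weaker or the stronger.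

Compound 3, `O=C(Nc1c(O)cccc1-c1nc2c(C(=O)O)cccc2o1)c1cc(-c2ccccc2)on1`, is not yet measured in this assay. Relative to compound 1 the change is 5-phenyl-1,2-oxazol-3-yl in place of 3-fluoropyridin-2-yl on a carbonyl carbon. Going by the values given here, the only measured step, from compound 1 to compound 2, also exchanges the aryl group on the carbonyl carbon and moved the number by a 1.0-fold higher number from compound 1 to compound 2 (0.01 log units; within the scatter), which is no movement beyond the scatter. Among the compounds with values here, that single step is the only guide, and it does not involve the 5-phenyl-1,2-oxazol-3-yl group, so the guidance is weak.

For compound 3 the expectation is therefore a step of about a 1.3-fold lower number from compound 1 to compound 3 (0.11 log units; within the scatter), that is, little or no change beyond the scatter, with a wide range to allow for the larger entering group. Compound 3 is estimated at 160000 nM, with a range from 60000 nM to 350000 nM.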

Compound 3, half-maximal inhibitory concentration: 141000 nM
The estimate for compound 3 lay 1.1-fold (0.05 log units) above the measured number, within the range that was stated.
By their numbers in this assay, from the lowest: compounds 3, 1 and 2 (each within the scatter of the next).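

The acyl position, on a carbonyl carbon whose other neighbour is an amide-type nitrogen, now carries 5-phenyl-1,2-oxazol-3-yl, which has 11 heavy atoms and two aromatic rings, against the 7 heavy atoms and single ring of 3-fluoropyridin-2-yl. Even so, this assay gives a 1.4-fold lower number from compound 1 to compound 3 (0.16 log units; within the scatter) and a 1.5-fold lower number from compound 2 to compound 3 (0.17 log units; within the scatter), so both steps stay within the scatter and the three amides cannot be ordered, which extends the flat reading from a swap of one single aromatic ring for another to an entering group with a second aromatic ring and a five-membered ring with 2 hetero atoms. No supporting data bear on why these numbers stay together.

The compounds shown leave open whether this flat reading holds for an acyl group with no aromatic ring at all, such as a saturated amine like piperidine, a longer alkyl chain or a group carrying a second carboxylic acid. They also leave open whether the number would move with a change elsewhere on the shared core, since the hydroxyl and the carboxylic acid are common to all three compounds.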